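The source may report more compounds than this note shows. Statements on the series, on what has been measured and on what is new or still open speak of the compounds shown alone.

Three compounds have been measured:
compound 1, `Nc1cc(N)c2nc(-c3ccccc3)c(Oc3ccc(Cl)c(Cl)c3)nc2c1`, with 3470 nM;
compound 2, `CCOC(=O)[C@H](CCC(=O)O)NC(=O)c1ccc(Sc2nc3cc(N)cc(N)c3nc2-c2ccccc2)cc1`, with 339 nM;
compound 3, `COc1ccc(CNc2nc3cc(N)cc(N)c3nc2-c2ccccc2)cc1`, with 4170 nM.

These numbers come from a functional assay on RPMI8266 cells (Homo sapiens) for inhibition, read by sulforhodamine B assay, with a stated time of 48 h; on this read-out higher numbers stand for weaker inhibition of growth and lower numbers for stronger inhibition of growth. Compound 1 gives the second highest of the three. Its nearest neighbour is compound 3, whose number is slightly higher but within the usual scatter of repeated measurements, so the two cannot be told apart. Compound 2 stands furthest away, with a markedly lower number, a gap well beyond the scatter.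

Compound 4, `Nc1cc(N)c2nc(-c3ccccc3)c(Sc3ccc(Cl)c(Cl)c3)nc2c1`, has not been measured. It differs from compound 1 in one place: (3,4-dichlorophenyl)sulfanyl in place of 3,4-dichlorophenoxy on an aromatic carbon. Compound 2 also carries a sulfur-linked aryl group on the shared core, with 339 nM, but its aryl group bears a different substituent; what the sulfur link alone contributes is not shown by any measured pair. The expected step is a 2.3-fold lower number from compound 1 to compound 4 (0.36 log units; beyond the scatter), of modest size toward stronger inhibition, though a step within the scatter would not surprise. Compound 4 is therefore expected to give 1500 nM, within a range from 500 nM to 5000 nM.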

Compound 4, concentration for 50% growth inhibition: 3800 nM
Compound 4: middle estimate off by 2.5-fold (0.40 log units), on the low side; low and high end bracket the measured number.
By their numbers in this assay, from the lowest: compound 2; then compounds 1, 4 and 3 (each within the scatter of the next).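

Among the compounds shown here, this is the first matched pair at this position, so the exchange of the linking atom can be read directly, which no earlier compound allowed. Putting (3,4-dichlorophenyl)sulfanyl in place of 3,4-dichlorophenoxy on this aromatic carbon gives a 1.1-fold higher number from compound 1 to compound 4 (0.04 log units; within the scatter) in this assay and so, with the 3,4-dichlorophenyl ring kept, the oxygen link and the sulfur link cannot be told apart on this read-out. Nothing available offers a reason for this result.

The compounds shown leave open whether a methylene link in place of the oxygen or sulfur would behave the same way on this carbon. They also do not show whether a nitrile or a methyl group in place of the two chlorines would change the number with either link.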